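The source may report more compounds than this note shows. Statements on the series, on what has been measured and on what is new or still open speak of the compounds shown alone.

Measured compounds in the series:

compound 1, `N#Cc1cccc(C(=O)NCN2CCC(c3cccc[n+]3[O-])CC2)c1`, 840 nM
compound 2, `O=C(CN1CCC(c2cccc[n+]2[O-])CC1)Nc1ccc(F)cc1F`, 103 nM
compound 3, `c1ccc(C2CCN(Cc3nc4ccccc4[nH]3)CC2)nc1`, 12 nM

In a functional assay on HEK293 cells for agonist activity at D(4) dopamine receptor (Homo sapiens), read by FLIPR (a higher number here means that more compound is needed for the effect, a lower number that less compound is needed), compound 2 stands second highest of the three numbers. Its nearest neighbour is compound 1, which gives a higher number, a gap beyond the usual scatter; furthest away is compound 3, which gives a lower number, again beyond the scatter. Among the compounds with values here, no two of the measured compounds differ in a single place, so no single-change step can be read off directly.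

Compound 4, `O=C(CN1CCC(c2cccc[n+]2[O-])CC1)Nc1ccccc1F`, is the next compound to be measured in this assay. It is derived from compound 2 by one change: hydrogen in place of fluoro on an aromatic carbon. The 2,4-difluorophenyl thus becomes a 2-fluorophenyl; the rest of the molecule is unchanged.

Nothing in the measured set shows what the loss of a single fluoro at this place does. The expected step of a 1.6-fold higher number from compound 2 to compound 4 (0.19 log units; within the scatter) is small, if anything towards a slightly higher number, and is expected to stay close to the scatter. Compound 4 is expected at about 160 nM, with a range from 60 nM to 450 nM.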

Compound 4, half-maximal effective concentration: 270 nM
Estimate against measurement, compound 4: 1.7-fold (0.23 log units) below; the measured number falls inside the stated range.
By their numbers in this assay, from the lowest: compound 3; then compound 2; then compound 4; then compound 1.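

In this assay, within the data shown here, hydrogen in place of fluoro on the aromatic carbon para to a large group gives a 2.6-fold higher number from compound 2 to compound 4 (0.42 log units; beyond the scatter), the first single-change step that can be read. This fluoro therefore has a measurable bearing on the read-out: the step is modest but beyond the scatter, and the 2,4-difluorophenyl needs less compound than the 2-fluorophenyl. No available evidence bears on the origin of this step.

The compounds shown leave open whether chloro, methyl or methoxy on this same carbon would match fluoro, and what the plain phenyl, with the remaining fluoro also replaced by hydrogen, would give. Among these compounds, also open is whether a step of this size would carry over to other amide linkers, such as the one in compound 1, whose aromatic ring carries a nitrile rather than fluoro.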